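A second methoxy on compound 1

This account rests on a few compounds, and the source may have more. Where it says the series, first, only, none or still open, it means among the compounds named here.

Measured in a functional assay on SMMC-7721 cells (Homo sapiens) for inhibition, read by CCK-8 assay, with a stated time of 72 h, tested at 8 uM; on this read-out lower numbers stand for less inhibition of growth and higher numbers for more inhibition of growth at the one concentration tested:
- compound 1 `COc1ccc(SCc2ccc(C(=O)Nc3ccccc3N)cc2)cc1`: 80.1%
- compound 2 `Nc1ccccc1NC(=O)c1ccc(CSc2ccc(Br)cc2)cc1`: 25.3%

Compound 1 stands highest of the two measured compounds, clear of compound 2 beyond the scatter. Compound 3 `COc1ccc(SCc2ccc(C(=O)Nc3ccccc3N)cc2)cc1OC` keeps the core of compound 1 and makes one change, methoxy in place of hydrogen on an aromatic carbon. For the measured compounds named here, only one measured step bears on it, a number 54.8 percentage points lower from compound 1 to compound 2 (beyond the scatter), for bromo in place of methoxy. That large step replaces the methoxy rather than adding to it, so it shows only that this assay can move far on a single change. A moderate fall is expected, an estimated a number 15.1 percentage points lower from compound 1 to compound 3 (beyond the scatter). The estimate for compound 3 is 65%, within an expected range of 40% to 85%.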

Compound 3, percent growth inhibition at one concentration: 78.9%
The estimate for compound 3 lay 13.9 percentage points below the measured number; the range from low to high includes it.
By their numbers in this assay, from the lowest: compound 2; then compounds 3 and 1 (each within the scatter of the next).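

In this assay the second methoxy, ortho to a methoxy group, gives a number 1.2 percentage points lower from compound 1 to compound 3 (within the scatter) and so shows that this position on the aromatic ring takes an added methoxy with the number held within the scatter. The earlier step showed only what bromo in place of the methoxy does, not what an addition beside it does. No measurement on hand bears on why this is so. On these data alone, whether an amine, a carboxylic acid or a longer chain such as ethoxy would be accepted at this position stays open, as does whether bromo here would match the methoxy.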